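The source may hold more compounds than are shown below. What is called first, only, known or untested is meant among the compounds shown, and "the series" means these compounds.

In a functional assay on HeLa cells (Homo sapiens) for inhibition, read by MTT assay, with a stated time of 72 h (a lower number here means a stronger inhibitor, a higher number a weaker inhibitor), compound 1 (`COc1cc(OC)c(OC)cc1/C=C/C(=O)c1ccc(Cl)cc1`) gives 36500 nM, compound 2 (`COc1cc(OC)c(OC)cc1/C=C/C(=O)c1cc(OC(C)=O)ccc1OC(C)=O`) gives 57900 nM, and compound 3 (`COc1cc(OC)c(OC)cc1/C=C/C(=O)c1cc(Cc2ccccc2)cc(Cc2ccccc2)c1`) gives 26900 nM. Compound 1 stands within the usual scatter of each of the other two. Compound 4 (`COc1cc(OC)c(OC)cc1/C=C/C(=O)c1ccccc1`) has not yet been measured. It differs from compound 1 by hydrogen in place of chloro on an aromatic carbon, with hydrogen in place of chloro on an aromatic carbon, para to a large group. For the measured compounds named here, no measured pair shows this change on its own, so the expectation rests on compound 1 at 36500 nM, and no shift beyond the scatter is anticipated. The expected step is a 1.1-fold higher number from compound 1 to compound 4 (0.04 log units; within the scatter). For compound 4 the estimated value is 40000 nM, with an expected range of 18000 nM to 90000 nM.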

Compound 4, half-maximal inhibitory concentration: > 150000 nM
Compound 4 gave a limit, no number; the forecaster's own chance of this, stated with the estimate: 10%; middle value at least 3.7-fold (0.57 log units) from the limit.
By their numbers in this assay, from the lowest: compounds 3, 1 and 2 (each within the scatter of the next, the first and the last beyond it). At a limit, above all of these: compound 4.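

The reading for compound 4 in this assay is a limit and not a number: the limit of > 150000 nM in this assay, at which 1 of the 4 values shown sits. Even so, this position, para to a large group, is not indifferent to what it carries: hydrogen in place of chloro gives an at least 4.1-fold higher number from compound 1 to compound 4 (0.61 log units; beyond the scatter) and this is the only single-place change shown. How far the phenyl of compound 4 stands from the 4-chlorophenyl of compound 1 has no upper bound here. Still open, going by these compounds, is whether chloro is particular at this position, or whether bromo or an amine there would match compound 1.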